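The source may hold more compounds than are shown below. What is called first, only, known or untested is meant among the compounds shown, and "the series" means these compounds.

In a functional assay on 3T3-L1 cells (Mus musculus) for inhibition, with a stated time of 20 min, tested at 20 uM (on this read-out lower numbers stand for less inhibition and higher numbers for more inhibition at the one concentration tested (going by the name of the read-out)), two compounds have been measured so far. Compound 1 `O=S(=O)(c1ccc(F)cc1)n1cc(CNCc2cccc(F)c2F)c2ccccc21` gives 21% in this assay. Compound 2 `Cc1ccc(S(=O)(=O)n2cc(CN(Cc3ccccc3)Cc3cccc(F)c3F)c3ccccc32)cc1` gives -13.1% in this assay, the lower of the two numbers, and compound 1 stands above it by a margin beyond the usual scatter of repeated measurements. Compound 3 `Cc1ccc(S(=O)(=O)n2cc(CNCc3cccc(F)c3F)c3ccccc32)cc1` has not yet been measured in this assay. It differs from compound 2 in a single place: hydrogen in place of benzyl on an amine nitrogen. Among the measured compounds shown here, compound 1 likewise carries a hydrogen rather than a benzyl on its amine nitrogen, and compound 1 at 21% lies well above compound 2, which is the only guide available for the present step. The step from compound 2 to compound 3 in this assay is therefore expected to be upward and beyond the scatter, about a number 28.1 percentage points higher from compound 2 to compound 3 (beyond the scatter). Compound 3 is estimated to give 15% in this assay, with a likely range from -5% to 35%.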

Compound 3, a percentage reported as inhibition, at one concentration (the size of the read-out at that concentration, not a potency): 46%
For compound 3 the middle estimate is 31 percentage points below the measured one; the measured number lies above the stated range.
By their numbers in this assay, from the lowest: compound 2; then compound 1; then compound 3.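

With only compound 1 and compound 2 in hand, the benzyl on the amine nitrogen could not be separated from the difference on the aromatic ring, since those two compounds differ in both places. In this assay, hydrogen in place of benzyl on the amine nitrogen now stands alone as a number 59.1 percentage points higher from compound 2 to compound 3 (beyond the scatter) and so accounts for a large rise without any change elsewhere, while methyl in place of fluoro on an aromatic carbon gives a number 25 percentage points higher from compound 1 to compound 3 (beyond the scatter) with the hydrogen on the amine nitrogen kept in both compounds. No data here explain either step.

The compounds shown leave open whether a methyl or an acetyl on the amine nitrogen would read closer to hydrogen or to benzyl. They also leave open how a chloro or a methoxy on that aromatic carbon would compare with methyl and fluoro.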